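A few compounds are considered here, and "the series" means these few. Any claim that something is new, unique, unknown or untested is made for them only; others in the source may bear on it.

Measured so far:
compound 1, `O=c1c2ccccc2nc(-c2ccccc2)n1/N=C/c1cccc(OCc2ccccc2)c1`, 300 mg/kg;
compound 2, `COc1cccc(/C=N/n2c(-c3ccccc3)nc3ccccc3c2=O)c1`, 100 mg/kg.

In a functional assay on the whole organism (strain albino CF-1) with Mus musculus as the target, in the maximal electroshock model, with a stated time of 4 h (a higher number here means that more compound is needed for the effect, a lower number that less compound is needed), compound 2 gives the lower of the two numbers, and compound 1 sits a 3.0-fold lower number from compound 1 to compound 2 (0.48 log units; beyond the scatter) away. Compound 3, `O=c1c2ccccc2nc(-c2ccccc2)n1/N=C/c1cccc(O)c1`, differs from compound 2 by hydrogen in place of methyl on an oxygen on an aromatic ring. For the measured compounds named here, the only measured step, a 3.0-fold lower number from compound 1 to compound 2 (0.48 log units; beyond the scatter), also trimmed this side chain, but it removed a phenyl, not a methyl, so it bears on the new change only loosely. The expected step is no change at the digits printed from compound 2 to compound 3 (within the scatter), with no clear direction beyond the scatter. Compound 3 is therefore estimated at about 100 mg/kg, within 50 mg/kg to 300 mg/kg.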

Compound 3, minimum effective dose: 100 mg/kg
For compound 3 middle estimate and measured number coincide at the digits printed, and the stated range covers the measured number.
By their numbers in this assay, from the lowest: compounds 2 and 3 (each within the scatter of the next); then compound 1.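

In this assay, the change from methoxy to hydroxy gives no change at the digits printed from compound 2 to compound 3 (within the scatter), so the methyl on this oxygen can go without a readable shift. Hydrogen in place of benzyl gives a 3.0-fold lower number from compound 1 to compound 3 (0.48 log units; beyond the scatter), which sets compound 1 apart, while the small methyl and the bare hydrogen cannot be told apart here. No supporting measurement accounts for this. From the compounds shown here alone, how an ethyl on this oxygen would read remains open, between the methyl and the benzyl in size. An amine in place of the hydroxy also remains untested in the compounds shown.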